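Swapping the Aryl Group on a Weak Breast-Cancer Cell Inhibitor

The source may report more compounds than this note shows. Statements on the series, on what has been measured and on what is new or still open speak of the compounds shown alone.

Within the data shown here, compound 1 `CN(C)CCn1c(=O)c(=Cc2ccc(F)c(F)c2)s/c1=C1\C(=O)Nc2cc(F)ccc21` gives 25000 nM in a functional assay on MDA-MB-231 cells (Homo sapiens) for inhibition, read by MTT assay, with a stated time of 72 h (on this read-out higher numbers stand for weaker inhibition and lower numbers for stronger inhibition), the highest of the two numbers measured so far. Compound 2 `CCN(CC)CCCn1c(=O)c(=Cc2ccc(F)c(F)c2)s/c1=C1\C(=O)Nc2cc(F)ccc21` gives 2900 nM in this assay; the step of an 8.6-fold lower number from compound 1 to compound 2 (0.94 log units; beyond the scatter) concerns the amine on the chain, not the aryl group. Compound 3 `COc1ccc(OC)c(C=c2s/c(=C3\C(=O)Nc4cc(F)ccc43)n(CCN(C)C)c2=O)c1` differs from compound 1 by 2,5-dimethoxyphenyl in place of 3,4-difluorophenyl on a double-bonded chain carbon bound to an aromatic carbon. Among the measured compounds shown here, no measured step touches this position, so the expectation rests on compound 1 alone. A step of no change at the digits printed from compound 1 to compound 3 (within the scatter) is expected, meaning no change beyond the scatter. Compound 3 is therefore estimated at 25000 nM in this assay, within 6000 nM to 100000 nM.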

Compound 3, half-maximal inhibitory concentration: 14500 nM
Compound 3: middle estimate off by 1.7-fold (0.24 log units), on the high side, within the range that was stated.
By their numbers in this assay, from the lowest: compound 2; then compounds 3 and 1 (each within the scatter of the next).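

Putting 2,5-dimethoxyphenyl in place of 3,4-difluorophenyl gives a 1.7-fold lower number from compound 1 to compound 3 (0.24 log units; within the scatter) in this assay, so this position takes the exchange with no shift that can be told from the scatter. The entering group has 2 hydrogen-bond acceptors and the leaving group 0, yet the read-out does not separate the two compounds. Nothing available here bears on this result.

Open, on these data alone, is whether the same exchange would read alike with the amine chain of compound 2. Also open, as far as these compounds go, is what a phenyl carrying a carboxylic acid would do here.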